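Taking the methoxycarbonyl off compound 1

The source may report more compounds than this note shows. Statements on the series, on what has been measured and on what is new or still open speak of the compounds shown alone.

In an ADME assay on J774 cells (Mus musculus) for cytotoxicity (a lower number here means that less compound is needed, a higher number that more compound is needed for the effect), compound 1 `CCCCc1ccc2[nH]cc(C(=O)OC)c(=O)c2c1` gives > 20000 nM as its reading, which is a limit and not a number. Compound 2 `COC(=O)c1c[nH]c2ccccc2c1=O` gives > 20000 nM as its reading, again a limit. Both compounds therefore rest on the limit of > 20000 nM in this assay, at which 2 of the 2 values shown sit, with no true number yet in hand.

Compound 3 `CCCCc1ccc2[nH]ccc(=O)c2c1` carries hydrogen in place of methoxycarbonyl on an aromatic carbon, and its difference from compound 1 is hydrogen in place of methoxycarbonyl on an aromatic carbon in full. Among the compounds with values here, the one measured step that bears on this, hydrogen in place of butyl on an aromatic carbon, is a step that the two limits leave unreadable from compound 1 to compound 2 and so hands on no size. It also removes a different group, so its bearing is only indirect. On that thin basis no step beyond the scatter is expected in this assay in either direction, and compound 3 will most likely sit at the same limit. The expected step is a step that the limit leaves unreadable from compound 1 to compound 3 and no more. For compound 3 the estimate is 25000 nM with an expected range from 12000 nM to 50000 nM as a plain expectation.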

Compound 3, half-maximal effective concentration: > 20000 nM
Compound 3 was reported as a limit (the forecaster's own chance of this, stated with the estimate: 80%); the middle value is on the limit's open side.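

Within the data shown here, compound 3, like compound 1, is reported in this assay only as a limit, so no step between the two can be read, and compound 2 adds no readable step either: the limit of > 20000 nM in this assay, at which 3 of the 3 values shown sit. The compounds shown leave open where the true half-maximal effective concentration of each lies, and so whether removing the methoxycarbonyl or the butyl changes it at all.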